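Two-ring amine group in place of cyclooctylamino

The source may report more compounds than this note shows. Statements on the series, on what has been measured and on what is new or still open speak of the compounds shown alone.

In a functional assay on K562 cells (Homo sapiens) for antiproliferative activity, read by CellTiter-Glo, with a stated time of 72 h (a lower number here means that less compound is needed, a higher number that more compound is needed for the effect), compound 1 `CCC(C)Nc1ncnc2c1ncn2[C@@H]1O[C@H](COS(N)(=O)=O)[C@@H](O)[C@H]1O` gives > 1000 nM as its result, which is a limit of the assay and not a number. Within the data shown here, compound 2 `NS(=O)(=O)OC[C@H]1O[C@@H](n2cnc3c(NC4CCCCCCC4)ncnc32)[C@H](O)[C@@H]1O` gives 380 nM and so holds the only actual number so far. Among the measured compounds shown here, the one measured step, an at least 2.6-fold lower number from compound 1 to compound 2 (0.42 log units; beyond the scatter), puts cyclooctyl in place of sec-butyl on the nitrogen and bears on this same substituent, though it rests on a limit. The change to compound 3 `NS(=O)(=O)OC[C@H]1O[C@@H](n2cnc3c(N4CCC5CCCCC5C4)ncnc32)[C@H](O)[C@@H]1O` sits on an aromatic carbon of the shared core and reads a group of 10 heavy atoms (9 carbon, 1 nitrogen; one six-membered non-aromatic ring of carbon only, one six-membered non-aromatic ring with 1 hetero atom) in place of a group of 9 heavy atoms (8 carbon, 1 nitrogen; one eight-membered non-aromatic ring of carbon only), on an aromatic carbon in full. Compound 3 keeps a ring group in this place, and with compound 2 at 380 nM as the reference, no step beyond the scatter is expected in this assay, on thin support. The expected change is a 1.3-fold higher number from compound 2 to compound 3 (0.12 log units; within the scatter) on this estimate. The estimate for compound 3 is 500 nM with an expected range from 150 nM to 1800 nM for the coming measurement.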

Compound 3, half-maximal effective concentration: > 1000 nM
Compound 3: no number, only a limit (the forecaster's own chance of this, stated with the estimate: 30%); middle value at least 2.0-fold (0.30 log units) away from the limit.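

In this assay, a ring group in this place does not by itself keep the number of compound 2, as the change to the two-ring amine group gives an at least 2.6-fold higher number from compound 2 to compound 3 (0.42 log units; beyond the scatter). The result for compound 3 is a limit and not a number, so this step has only a lower bound on its size, and the step between compound 1 and compound 3 cannot be read. Only compound 2 gives an actual number at this position, and the other results stop at one shared boundary: the limit of > 1000 nM in this assay, at which 2 of the 3 values shown sit.

The change from compound 2 to compound 3 alters the ring system and also goes from 1 hydrogen-bond donor to 0, and these compounds cannot separate the two. A methyl on the nitrogen of the cyclooctylamino group, or a cyclohexylamino group, would leave open questions at this position that the compounds shown do not answer.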